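This account rests on a few compounds, and the source may have more. Where it says the series, first, only, none or still open, it means among the compounds named here.

Compound 1, `O=C(CCCCCCCN1C(=O)c2ccccc2C1=O)NO`: 71.4 nM
Compound 2, `O=C(CCCCCCCCC(=O)c1ccccc1)NO`: 135 nM
Compound 3, `COc1ccc(C(=O)CCCCCCCC(=O)NO)cc1`: 15 nM

All three were tested in an assay on isolated protein for inhibition of histone deacetylase 8 (Homo sapiens); on this read-out higher numbers stand for weaker inhibition and lower numbers for stronger inhibition. Among these three numbers compound 3 stands lowest, that is, it is the strongest inhibitor of the set. Compound 1 comes nearest to it, yet its number is clearly higher and the gap lies beyond the scatter; compound 2 is furthest away, with a gap that also lies beyond the scatter.

Compound 4, `O=C(CCCCCCCC(=O)c1ccc(C(F)(F)F)cc1)NO`, has not yet been measured in this assay. It differs from compound 3 in a single place: trifluoromethyl in place of methoxy on an aromatic carbon. Within the data shown here, no measured pair in this set makes exactly that change, so the step cannot be read off a neighbouring pair. What the numbers do show is that compound 3, which carries the methoxy group, gives 15 nM, while compound 2, whose ring carries no such group, gives 135 nM; the methoxy group thus goes with the lower number. Whether a trifluoromethyl group keeps that advantage is open. The step from compound 3 to compound 4 in this assay is expected to be a 2.7-fold higher number from compound 3 to compound 4 (0.43 log units; beyond the scatter), a modest rise in the number, though a step within the scatter would not surprise. Compound 4 is therefore estimated at 40 nM, with a likely range from 12 nM to 130 nM.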

Compound 4, half-maximal inhibitory concentration: 45 nM
Compound 4: middle estimate off by 1.1-fold (0.05 log units), on the low side; measured number inside the range.
By their numbers in this assay, from the lowest: compound 3; then compounds 4, 1 and 2 (each within the scatter of the next, the first and the last beyond it).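

In this assay, trifluoromethyl in place of methoxy on the aromatic carbon gives a 3.0-fold higher number from compound 3 to compound 4 (0.48 log units; beyond the scatter), which means weaker inhibition. Among these compounds, this is the first direct view of this place on the ring, para to a large group, with everything else in the molecule held the same: the number responds to the group placed there, so the position is not indifferent to the exchange, although the step is modest and compound 4 remains an inhibitor. The change swaps a group that has a hydrogen-bond acceptor for one that has none and also brings more heavy atoms, but nothing available here says which of these differences, if either, lies behind the rise.

With one exchange at this place, the compounds shown do not reveal how a bare ring on the same chain, or an amine, a chlorine atom or a nitrile in the same spot, would compare with compound 3. They also leave open whether the same exchange would produce a step of similar size on a shorter or longer chain.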